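Swapping the aryl amide for a ring amine in a frizzled-related protein 1 series

A few compounds are considered here, and "the series" means these few. Any claim that something is new, unique, unknown or untested is made for them only; others in the source may bear on it.

Compound 1 `O=C(c1ccc(Cl)cc1)N1CCC(NS(=O)(=O)c2cc(S(=O)(=O)c3ccccc3)ccc2C(F)(F)F)CC1`: 1800 nM
Compound 2 `O=C(O)CCCC(=O)N1CCC(NS(=O)(=O)c2cc(S(=O)(=O)c3ccccc3)ccc2C(F)(F)F)CC1`: 570 nM

Of the compounds shown here, two sharing one core have been measured in an assay on U2OS cells for inhibition of secreted frizzled-related protein 1 (Homo sapiens), read by a luciferase reporter, with a stated time of 18 h; on this read-out higher numbers stand for an effect only at larger amounts of compound and lower numbers for an effect already at smaller amounts. Compound 1 gives 1800 nM, the highest of the two numbers, and compound 2 gives 570 nM. Within the data shown here, the single step between them, a 3.2-fold lower number from compound 1 to compound 2 (0.50 log units; beyond the scatter), shows that replacing the aryl group on the carbonyl carbon with a short acid-bearing chain made the compound act at smaller amounts.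

Compound 3 `O=C([C@@H]1CCNC1)N1CCC(NS(=O)(=O)c2cc(S(=O)(=O)c3ccccc3)ccc2C(F)(F)F)CC1` is not yet measured. Its change from compound 1 is pyrrolidin-3-yl in place of 4-chlorophenyl on a carbonyl carbon. Like the step to compound 2, this removes the same aryl group and puts a small group carrying a hydrogen-bond donor and acceptor in its place, so a lowering of the number of similar, modest size is expected. Compound 3 is therefore estimated at 700 nM, between 250 nM and 2500 nM, a step of a 2.6-fold lower number from compound 1 to compound 3 (0.41 log units; beyond the scatter), expected because of the precedent a 3.2-fold lower number from compound 1 to compound 2 (0.50 log units; beyond the scatter).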

Compound 3, half-maximal effective concentration: 380 nM
Compound 3: the middle estimate sits 1.8-fold (0.27 log units) above what was measured; the measured number falls inside the stated range.
By their numbers in this assay, from the lowest: compounds 3 and 2 (each within the scatter of the next); then compound 1.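

Compound 3 shows that the lowering seen with compound 2 is not tied to one kind of replacement: in this assay, pyrrolidin-3-yl in place of 4-chlorophenyl on the carbonyl carbon gives a 4.7-fold lower number from compound 1 to compound 3 (0.68 log units; beyond the scatter) and so also beats the aryl amide. The acid chain is also not required for this lowering, since the comparison of the two replacements gives a 1.5-fold lower number from compound 2 to compound 3 (0.18 log units; within the scatter) and leaves 3-carboxypropyl and pyrrolidin-3-yl indistinguishable here. No measurement available here explains why either replacement lowers the number.

Going by these compounds, whether the ring nitrogen matters, or only the loss of 4-chlorophenyl, stays open, and a cyclopentyl group, a carbon-only ring, on the same carbonyl carbon would separate the two. On these data alone, the role of the defined stereocentre also stays open, as only one mirror-image form of pyrrolidin-3-yl appears here.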